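The source may report more compounds than this note shows. Statements on the series, on what has been measured and on what is new or still open speak of the compounds shown alone.

Working notes on the series. Compound 1 `COc1cc(N/C=C\C(=O)c2cn(-c3ccccc3)nc2-c2ccc(Cl)cc2)cc(OC)c1OC` gives 5640 nM in a functional assay on A549 cells (Homo sapiens) for antiproliferative activity, read by MTT assay, with a stated time of 48 h; on this read-out higher numbers stand for weaker inhibition and lower numbers for stronger inhibition. Compound 2 `COc1ccc(-c2nn(-c3ccccc3)cc2C(=O)/C=C\Nc2ccc(Cl)cc2)cc1` gives 2970 nM in this assay, and the two values lie within the usual scatter of each other. Compound 3 `COc1ccc(-c2nn(-c3ccccc3)cc2C(=O)/C=C\Nc2ccc(C(F)(F)F)cc2)cc1` reaches only the limit of this assay, > 50000 nM; this is a limit, not a number (the limit of > 50000 nM in this assay, at which 1 of the 3 values shown sits). Among the measured compounds shown here, the one measured step, an at least 16-fold higher number from compound 2 to compound 3 (1.22 log units; beyond the scatter), sits on the aniline ring and not at the place changed here. Compound 4 `COc1cc(N/C=C\C(=O)c2cn(-c3ccccc3)nc2-c2cc(OC)c(OC)c(OC)c2)cc(OC)c1OC` differs from compound 1 by 3,4,5-trimethoxyphenyl in place of 4-chlorophenyl on an aromatic carbon. For the measured compounds named here, no measured step touches this position, so no direction can be taken from the series; the expectation for compound 4 in this assay is a step of a 1.6-fold lower number from compound 1 to compound 4 (0.21 log units; within the scatter), within or near the scatter. Compound 4 is therefore estimated at 3500 nM, with a range of 800 nM to 15000 nM.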

Compound 4, half-maximal inhibitory concentration: 7980 nM
Beside the measured number, compound 4's estimate is 2.3-fold (0.36 log units) below it, within the range that was stated.
By their numbers in this assay, from the lowest: compounds 2, 1 and 4 (each within the scatter of the next, the first and the last beyond it). At a limit, above all of these: compound 3.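

The step of a 1.4-fold higher number from compound 1 to compound 4 (0.15 log units; within the scatter) in this assay gives this position its first measured reading, and it does not separate 3,4,5-trimethoxyphenyl from 4-chlorophenyl. At this place on the core of compound 1, the larger group with its added hydrogen-bond acceptors therefore leaves the value within the scatter. Nothing measured here accounts for this result.

Going by these compounds, it remains open whether an amine or a carboxylic acid on this ring carbon would also stay within the scatter. Also open, on these data alone, is whether the same exchange would read alike with the aniline ring of compound 2.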